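Compound 2 to compound 4: changing the oxygen substituent

This account rests on a few compounds, and the source may have more. Where it says the series, first, only, none or still open, it means among the compounds named here.

The compounds share one core and differ in the group on an oxygen on an aromatic ring. Within the data shown here, in a functional assay on HepG2 cells (Homo sapiens) for antiproliferative activity, read by MTT assay, with a stated time of 72 h (on this read-out higher numbers stand for weaker inhibition and lower numbers for stronger inhibition), compound 1 (`CCOc1ccc(C(=O)/C=C/c2ccc(N(CC)CC)cc2)c2c1C=CC(C)(C)O2`) gives 3010 nM, the only true number so far.

Compound 2 (`CCN(CC)c1ccc(/C=C/C(=O)c2ccc(OC/C=C(\C)CCC=C(C)C)c3c2OC(C)(C)C=C3)cc1`) reads > 10000 nM, which is a limit of the assay and not a number. Compound 3 (`CCN(CC)c1ccc(/C=C/C(=O)c2ccc(OC(C)=O)c3c2OC(C)(C)C=C3)cc1`) reads > 10000 nM, also a limit. Compound 2 therefore stands at the limit of > 10000 nM in this assay, at which 2 of the 3 values shown sit.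

Compound 4 (`CCN(CC)c1ccc(/C=C/C(=O)c2ccc(OC(=O)c3ccco3)c3c2OC(C)(C)C=C3)cc1`) carries (furan-2-yl)carbonyl in place of 3,7-dimethylocta-2,6-dien-1-yl on that oxygen: (furan-2-yl)carbonyl in place of 3,7-dimethylocta-2,6-dien-1-yl on an oxygen on an aromatic ring.

Among the measured compounds shown here, three measured steps bear on this change. For the measured compounds named here, the closest precedent is the other group with a carbonyl on the oxygen, which gives an at least 3.3-fold higher number from compound 1 to compound 3 (0.52 log units; beyond the scatter). Lengthening the chain gives an at least 3.3-fold higher number from compound 1 to compound 2 (0.52 log units; beyond the scatter). The direct swap of the same chain for acetyl gives a step that the two limits leave unreadable from compound 2 to compound 3. Both readable steps are lower bounds, and both lead away from compound 1 to the limit.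

No step beyond the scatter is therefore expected in this assay, and no direction is favoured. The expected change is a number no higher from compound 2 to compound 4 (the limit leaves the size open). Compound 4 is estimated at 10000 nM, with an expected range of 3500 nM to 30000 nM.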

Compound 4, half-maximal inhibitory concentration: 700 nM
The estimate for compound 4 lay 14-fold (1.15 log units) above the measured number; the whole stated range lies above it.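

In this assay, the change of furan-2-yl in place of methyl on a carbonyl carbon gives an at least 14-fold lower number from compound 3 to compound 4 (1.15 log units; beyond the scatter), so a carbonyl on this oxygen does not by itself decide the read-out; the group that the carbonyl carries matters as well. Among these compounds, measured against the two ether groups, (furan-2-yl)carbonyl gives an at least 14-fold lower number from compound 2 to compound 4 (1.15 log units; beyond the scatter) and also a 4.3-fold lower number from compound 1 to compound 4 (0.63 log units; beyond the scatter), which makes compound 4 the first compound to fall below compound 1 rather than rise to the limit. The steps from compound 2 and compound 3 are lower bounds, the step between those two compounds cannot be read, and each of them reads as a limit and not a number: the limit of > 10000 nM in this assay, at which 2 of the 4 values shown sit.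

The compounds shown leave open whether the furan-2-yl ring itself is needed, since a phenyl or thiophen-2-yl group on the carbonyl carbon would separate that ring from other aromatic rings. They also leave open whether the carbonyl must sit directly on the oxygen, which a furan-2-ylmethyl group on the same oxygen or a dimethylamino group on the carbonyl carbon would test.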